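Adding one carbon to the amide side chain

The compounds below may be only part of what the source reports. "The series", "measured", "known", "first", "only" and "open" are said of these compounds alone.

Measured in a functional assay on NCI-H1975 cells (Homo sapiens) for antiproliferative activity, read by CCK-8 assay, with a stated time of 72 h; on this read-out lower numbers stand for stronger inhibition of growth and higher numbers for weaker inhibition of growth:
- compound 1 `CC[C@@H]1C(=O)N(C)c2cnc(-n3ccc4ccccc43)nc2N1C1CCCC1`: 28300 nM
- compound 2 `CCCNC(=O)c1ccc2c(ccn2-c2ncc3c(n2)N(c2ccn(C)n2)C(CC)C(=O)N3C)c1`: 11000 nM
- compound 3 `CC[C@@H]1C(=O)N(C)c2cnc(-n3ccc4cc(C(=O)NC(C)C)ccc43)nc2N1C1CCCC1`: 1840 nM

Compound 3 has the lowest number of the three, and compound 2 lies nearest to it. Compound 4 `CC[C@@H]1C(=O)N(C)c2cnc(-n3ccc4cc(C(=O)NCC(C)C)ccc43)nc2N1C1CCCC1` differs from compound 3 in one place: isobutyl in place of isopropyl on an amide-type nitrogen, with isobutyl in place of isopropyl on an amide-type nitrogen. Going by the values given here, one measured step bears on this change: a 15-fold lower number from compound 1 to compound 3 (1.19 log units; beyond the scatter), a large step beyond the scatter, with isopropylcarbamoyl in place of hydrogen on an aromatic carbon. Among the compounds with values here, that step shows what adding the whole group does, but no measured pair varies the chain on that nitrogen. The carbamoyl group itself stays in compound 4, so the expectation in this assay starts from compound 3 at 1840 nM, with a step no larger than the scatter and no firm direction. The expected change is a 1.1-fold higher number from compound 3 to compound 4 (0.04 log units; within the scatter). For compound 4 the estimated value is 2000 nM, with an expected range of 700 nM to 5500 nM.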

Compound 4, concentration for 50% growth inhibition: "not active" (no number reported)
For compound 4 the study gives words and no number; the estimate stays without a comparison.
By their numbers in this assay, from the lowest: compound 3; then compound 2; then compound 1.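

Going by these compounds alone, compound 4 is reported only in the words "not active", without a number, and no step from compound 3 to compound 4 can be read. The compounds shown leave open how the chain on the amide-type nitrogen bears on growth inhibition. No evidence here bears on this result.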